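Aryl variation on the shared core: limits only so far

The source may report more compounds than this note shows. Statements on the series, on what has been measured and on what is new or still open speak of the compounds shown alone.

Compound 3 `CN(c1cccc2c1CN(c1nc(Nc3ccc(C(F)(F)F)cc3)ncc1C(F)(F)F)C2)S(C)(=O)=O` is the reference point here. In an assay on Sf9 cells for inhibition of tyrosine-protein kinase receptor UFO (Homo sapiens), read by luminescence and ADP-Glo (on this read-out higher numbers stand for weaker inhibition and lower numbers for stronger inhibition), compound 3 gives only a limit of the assay, > 20000 nM. Compound 1 `COc1ccc(Nc2ncc(C(F)(F)F)c(N3Cc4cccc(N(C)S(C)(=O)=O)c4C3)n2)cc1C(F)(F)F` likewise gives a limit in this assay, > 20000 nM. Compound 2 `Cc1cc(Cl)ccc1Nc1ncc(C(F)(F)F)c(N2Cc3cccc(N(C)S(C)(=O)=O)c3C2)n1` also gives a limit, > 20000 nM. Accordingly a step that the two limits leave unreadable from compound 1 to compound 2, a step that the two limits leave unreadable from compound 1 to compound 3 and a step that the two limits leave unreadable from compound 2 to compound 3 cannot be read, since all three values sit at the limit of > 20000 nM in this assay, at which 3 of the 3 values shown sit. Compound 4 `CN(c1cccc2c1CN(c1nc(Nc3ccc(Cl)c(C(F)(F)F)c3)ncc1C(F)(F)F)C2)S(C)(=O)=O` carries 4-chloro-3-(trifluoromethyl)phenyl in place of 4-(trifluoromethyl)phenyl on a nitrogen on an aromatic ring. Among the measured compounds shown here, no measured step bears on this change in a readable way, so the series gives no direction for it; the working assumption is simply that compound 4 stays near the limit. Compound 4 is therefore estimated at 30000 nM, with a range from 5000 nM to 150000 nM. The step that the limit leaves unreadable from compound 3 to compound 4 is expected to be within the scatter.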

Compound 4, half-maximal inhibitory concentration: > 20000 nM
Compound 4: only a limit was reported; the forecaster's own chance of this, stated with the estimate: 75%; the middle value lies beyond the limit too.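

Compound 4 in this assay gives > 20000 nM, which is a limit of the assay. Its steps from compound 1, compound 2 and compound 3 cannot be read: the limit of > 20000 nM in this assay, at which 4 of the 4 values shown sit. The compounds shown leave open whether any aryl group on the shared core gives a measurable value.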